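The source may hold more compounds than are shown below. What is called first, only, known or untested is meant among the compounds shown, and "the series" means these compounds.

Compound 2 `C[C@@H](NC(=O)c1cccc(Cl)c1)[C@H]1CC[C@@H](c2ccnc3ccc(F)cc32)CC1` and compound 1 `C[C@@H](NC(=O)Nc1ccc(Cl)cc1)[C@H]1CC[C@@H](c2ccnc3ccc(F)cc32)CC1` share one core and differ only in the group carried on the carbonyl carbon. In an ADME assay on microsomes from liver (Homo sapiens) for metabolic stability, with a stated time of 10 min, tested at 0.5 uM (on this read-out lower numbers stand for a less stable compound and higher numbers for a more stable compound), compound 1 gives 52%, and compound 2 gives 39%, the lower of the two numbers; the step of a number 13 percentage points lower from compound 1 to compound 2 (beyond the scatter). Compound 3 `C[C@@H](NC(=O)C1CCCCC1)[C@H]1CC[C@@H](c2ccnc3ccc(F)cc32)CC1` is built from compound 2 by cyclohexyl in place of 3-chlorophenyl on a carbonyl carbon. For the measured compounds named here, only that one earlier step is known, and it concerns a different exchange, so it offers little direct guidance here. For compound 3 the expected step is a number 4 percentage points lower from compound 2 to compound 3 (within the scatter), not beyond the usual scatter. Compound 3 is therefore estimated at 35%, with a range from 15% to 55%.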

Compound 3, percent of the compound remaining: 6%
For compound 3 the middle estimate is 29 percentage points above the measured one; measured number outside the range, below it.
By their numbers in this assay, from the lowest: compound 3; then compound 2; then compound 1.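

In this assay, the group on the carbonyl carbon matters far more than the first pair suggested: cyclohexyl in place of 3-chlorophenyl gives a number 33 percentage points lower from compound 2 to compound 3 (beyond the scatter). Cyclohexyl in place of (4-chlorophenyl)amino gives a number 46 percentage points lower from compound 1 to compound 3 (beyond the scatter), so among these three compounds, the two chlorine-bearing aromatic groups both leave more compound remaining than cyclohexyl. No available data explain these drops.

As far as these compounds go, the exchange removes both the aromatic ring and the chlorine, so their separate contributions remain open. Also open, from the compounds shown here alone, is how plain phenyl or an amine-bearing cyclohexyl would behave in this assay.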